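Trimming the indole to a bare phenyl on the hydrazone

The source may hold more compounds than are shown below. What is called first, only, known or untested is meant among the compounds shown, and "the series" means these compounds.

Compound 1, `CN(C)CCn1cnnc1-c1cc(Oc2ccc(NC(=O)N/N=C/c3cc(C(C)(C)C)cc(C(C)(C)C)c3O)cc2F)ccn1`, gives 680 nM in a functional assay on HT-29 cells (Homo sapiens) for cytotoxicity, read by MTT assay, with a stated time of 72 h; a higher number here means a weaker inhibitor, a lower number a stronger inhibitor.
Compound 2, `CN(C)CCn1cnnc1-c1cc(Oc2ccc(NC(=O)N/N=C/c3cc(Br)c(O)c(Br)c3)cc2F)ccn1`, gives 2670 nM in this assay.
Compound 3, `CN(C)CCn1cnnc1-c1cc(Oc2ccc(NC(=O)N/N=C/c3c[nH]c4ccccc34)cc2F)ccn1`, gives 1300 nM in this assay.

All three share one core and differ only in the aromatic group attached to the carbon with a double bond to nitrogen. Compound 3 stands second highest of the three numbers: its gap to compound 1 lies within the scatter, while compound 2 gives a higher number, a 2.1-fold lower number from compound 2 to compound 3 (0.31 log units; beyond the scatter).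

Compound 4, `CN(C)CCn1cnnc1-c1cc(Oc2ccc(NC(=O)N/N=C/c3ccccc3)cc2F)ccn1`, has not yet been measured. It differs from compound 3 by phenyl in place of 1H-indol-3-yl on a carbon with a double bond to nitrogen. Going by the values given here, only one measured step concerns the same position, the one from compound 2 to compound 3, and that step was modest. Among the compounds with values here, no measured compound shows a plain phenyl at this position, so there is no direct precedent for the change; the other groups there all carry more atoms than phenyl, and the smallest of them, in compound 2, gives the highest number.

On that basis compound 4 is expected to give a somewhat higher number than compound 3, a step of a 1.9-fold higher number from compound 3 to compound 4 (0.28 log units; within the scatter) in this assay. The estimate for compound 4 is 2500 nM, within a range from 1000 nM to 6500 nM.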

Compound 4, half-maximal inhibitory concentration: 1120 nM
Beside the measured number, compound 4's estimate is 2.2-fold (0.35 log units) above it; measured number inside the range.
By their numbers in this assay, from the lowest: compounds 1, 4 and 3 (each within the scatter of the next); then compound 2.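

In this assay, replacing 1H-indol-3-yl with a bare phenyl on the carbon with a double bond to nitrogen removes the five-membered ring and the hydrogen-bond donor, yet the change stays within the scatter (a 1.2-fold lower number from compound 3 to compound 4 (0.06 log units; within the scatter)), so neither feature is required for a number at this level. The same bare phenyl also separates from the 3,5-dibromo-4-hydroxyphenyl group of compound 2 by more than the scatter, though only modestly (a 2.4-fold lower number from compound 2 to compound 4 (0.38 log units; beyond the scatter)), which shows that the higher number of compound 2 does not simply reflect the lack of a larger group, since the smaller phenyl gives the lower number here. Nothing available explains either result.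

Compound 2 carries its two bromine atoms and its hydroxyl group together, so these compounds cannot show whether the bromines, the hydroxyl or the pair goes with its higher number. On these data alone, how this position would respond to a phenyl bearing an amine or a carboxylic acid, or to a longer chain in place of the ring, also remains open.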